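Swapping the hydrazone aryl group on a methoxy core

The source may hold more compounds than are shown below. What is called first, only, known or untested is meant among the compounds shown, and "the series" means these compounds.

Three compounds sharing a quinazoline-type anilino core differ in two places: the group on the ring oxygen and the aryl group on the hydrazone arm. Compound 1 `CCN(CC)c1ccc(/C=N/NC(=O)Nc2cc3c(Nc4ccc(F)c(Cl)c4)ncnc3cc2O[C@H]2CCOC2)c(O)c1` carries the larger aryl group and the oxolan-3-yl ether; in a functional assay on MCF7 cells (Homo sapiens) for cytotoxicity, read by MTT assay, with a stated time of 72 h (a lower number here means a stronger inhibitor, a higher number a weaker inhibitor), compound 1 gives 15600 nM. Compound 2 `O=C(N/N=C/c1ccc(O)cc1)Nc1cc2c(Nc3ccc(F)c(Cl)c3)ncnc2cc1O[C@H]1CCOC1` keeps the same ether but has the smaller aryl group, and compound 2 gives 910 nM. This change, (4-hydroxyphenyl in place of 4-(diethylamino)-2-hydroxyphenyl on a carbon with a double bond to nitrogen), produced a 17-fold lower number from compound 1 to compound 2 (1.23 log units; beyond the scatter).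

Compound 3 `CCN(CC)c1ccc(/C=N/NC(=O)Nc2cc3c(Nc4ccc(F)c(Cl)c4)ncnc3cc2OC)c(O)c1` differs from compound 1 only by methyl in place of oxolan-3-yl on an oxygen on an aromatic ring, and compound 3 gives 27300 nM; the step of a 1.8-fold higher number from compound 1 to compound 3 (0.24 log units; within the scatter) shows the two ethers behave alike here.

Compound 4 `COc1cc2ncnc(Nc3ccc(F)c(Cl)c3)c2cc1NC(=O)N/N=C/c1ccc(O)cc1` is the not-yet-measured partner of compound 3: it makes the change 4-hydroxyphenyl in place of 4-(diethylamino)-2-hydroxyphenyl on a carbon with a double bond to nitrogen on the methoxy core. The place of the change is the same, word for word, as in the pair from compound 1 to compound 2, so this is the same change on a core that differs only by the ether. Since the ether swap barely moved the number, the step from compound 3 to compound 4 is expected to be close to the earlier one, and is estimated at a 17-fold lower number from compound 3 to compound 4 (1.23 log units; beyond the scatter). On that basis compound 4 is expected to give about 1600 nM, with a plausible range from 600 nM to 4500 nM. This rests on the step of a 17-fold lower number from compound 1 to compound 2 (1.23 log units; beyond the scatter) applied to the number of compound 3, which is 27300 nM.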

Compound 4, half-maximal inhibitory concentration: 28600 nM
Compound 4: the middle estimate sits 18-fold (1.25 log units) below what was measured; the whole stated range lies below it.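

On the methoxy core, placing 4-hydroxyphenyl where 4-(diethylamino)-2-hydroxyphenyl stood gives a 1.0-fold higher number from compound 3 to compound 4 (0.02 log units; within the scatter) in this assay, so the gain seen with the oxolan-3-yl ether does not carry over to this core: the same change on two cores in this assay, a 17-fold lower number (1.23 log units; beyond the scatter) from compound 1 to compound 2 and a 1.0-fold higher number (0.02 log units; within the scatter) from compound 3 to compound 4, 18-fold (1.25 log units) apart, beyond the scatter of two such steps. Read the other way, the ether change that made no clear difference with the larger aryl group gives a 31-fold higher number from compound 2 to compound 4 (1.50 log units; beyond the scatter) when 4-hydroxyphenyl is present: the same change on two cores in this assay, a 1.8-fold higher number (0.24 log units; within the scatter) from compound 1 to compound 3 and a 31-fold higher number (1.50 log units; beyond the scatter) from compound 2 to compound 4, 18-fold (1.25 log units) apart, beyond the scatter of two such steps. The two changes therefore do not act independently in these four compounds: the low number of compound 2 appears only when 4-hydroxyphenyl and the oxolan-3-yl ether occur together, but this rests on a single pair of ethers and a single pair of aryl groups in one cell assay, and it does not show why the pairing matters or whether it would hold for other groups.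

Going by these compounds, it remains open whether an ethyl group or a longer chain on the ring oxygen would behave like methyl or like oxolan-3-yl when 4-hydroxyphenyl is present. On these data alone, it also remains open whether an unsubstituted phenyl or a pyridyl group, on the carbon with a double bond to nitrogen, would show the same dependence on the ether.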